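Replacing the benzodioxin ring of compound 1 with plain phenyl

A few compounds are considered here, and "the series" means these few. Any claim that something is new, unique, unknown or untested is made for them only; others in the source may bear on it.

Compound 1 has the structure `O=C(c1ccc2c(c1)OCCO2)C1CCN(Cc2coc(-c3ccc(F)cc3)n2)CC1`. In an ADME assay on HEK293 cells (Homo sapiens) for cytotoxicity, read by MTT assay, with a stated time of 36 h (on this read-out higher numbers stand for weaker inhibition and lower numbers for stronger inhibition), compound 1 gives > 150 ug/mL, which is a limit of the assay rather than a number. Compound 2, with the structure `O=C(c1ccc2c(c1)OCCO2)C1CCN(Cc2coc(-c3ccc(C(F)(F)F)cc3)n2)CC1`, gives > 150 ug/mL in this assay, again a limit and not a number. Going by the values given here, this means that compound 1 stands at the limit of this assay, and the only other value shown, that of compound 2, sits at the same place: the limit of > 150 ug/mL in this assay, at which 2 of the 2 values shown sit. Among the compounds with values here, the one measured step, trifluoromethyl in place of fluoro on an aromatic carbon, is a step that the two limits leave unreadable from compound 1 to compound 2.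

Compound 3 has the structure `O=C(c1ccccc1)C1CCN(Cc2coc(-c3ccc(F)cc3)n2)CC1`. It differs from compound 1 by phenyl in place of 2,3-dihydro-1,4-benzodioxin-6-yl on a carbonyl carbon. Within the data shown here, no measured step touches this part of the shared core, so the only guide is that both measured compounds sit at the limit. On that basis the step from compound 1 to compound 3 is expected to be a number no higher from compound 1 to compound 3 (the limit leaves the size open), which is none beyond the scatter. Compound 3 is therefore estimated at 150 ug/mL in this assay, between 60 ug/mL and 300 ug/mL, most likely reported again only as a limit.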

Compound 3, half-maximal inhibitory concentration: > 150 ug/mL
Compound 3: a limit, no number; the forecaster's own chance of this, stated with the estimate: 75%; the middle value sits exactly at the limit.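

No step can be read between compound 1 and compound 3, because both are reported only as limits and not as numbers: the limit of > 150 ug/mL in this assay, at which 3 of the 3 values shown sit.

The compounds shown leave open at what concentration any of them would reach half-maximal inhibition in this assay, and whether phenyl in place of 2,3-dihydro-1,4-benzodioxin-6-yl changes that concentration at all.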